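Chromenone series: chain terminus and monoamine oxidase B inhibition

The source may report more compounds than this note shows. Statements on the series, on what has been measured and on what is new or still open speak of the compounds shown alone.

Measured compounds:
- compound 1 `O=C(O)COc1cc(=O)oc2cc(OCc3cccc(Cl)c3)ccc12`: 31600 nM
- compound 2 `O=c1cc(CCO)c2ccc(OCc3cccc(Cl)c3)cc2o1`: 7.41 nM
- compound 3 `O=c1cc(CCCl)c2ccc(OCc3cccc(Cl)c3)cc2o1`: 12.9 nM

Compound 3 sits second highest of the three numbers in an assay on brain (strain Sprague-Dawley) for inhibition of Amine oxidase [flavin-containing] B (Rattus norvegicus), read by spectrophotometry; on this read-out higher numbers stand for weaker inhibition and lower numbers for stronger inhibition; its nearest neighbour is compound 2, at a 1.7-fold higher number from compound 2 to compound 3 (0.24 log units; within the scatter), and its furthest is compound 1, at a 2400-fold lower number from compound 1 to compound 3 (3.39 log units; beyond the scatter). Compound 4 `O=C(O)CCc1cc(=O)oc2cc(OCc3cccc(Cl)c3)ccc12` is not yet measured. Relative to compound 3 it shows (carboxy in place of chloro on a saturated chain carbon, two bonds along the chain from an aromatic carbon).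

For the measured compounds named here, no measured pair maps this change directly. Going by the values given here, the step that bears on it most is the one from compound 1 to compound 3, a 2400-fold lower number from compound 1 to compound 3 (3.39 log units; beyond the scatter), and the parallel one a 4300-fold lower number from compound 1 to compound 2 (3.63 log units; beyond the scatter): the only compound here carrying a carboxy group, compound 1, gives 31600 nM, far above the two neutral chains. Compound 4 reintroduces a carboxy group, on a chain rather than through an ether oxygen, so a large rise in this assay is expected, a 230-fold higher number from compound 3 to compound 4 (2.37 log units; beyond the scatter), though the differing attachment leaves the size uncertain. Compound 4 is therefore estimated at 3000 nM, within 300 nM to 30000 nM.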

Compound 4, half-maximal inhibitory concentration: 1200 nM
For compound 4 the middle estimate is 2.5-fold (0.40 log units) above the measured one; the measured number falls inside the stated range.
By their numbers in this assay, from the lowest: compounds 2 and 3 (each within the scatter of the next); then compound 4; then compound 1.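

In this assay, carboxy in place of chloro or hydroxy on the saturated chain carbon raises the number steeply, with a 93-fold higher number from compound 3 to compound 4 (1.97 log units; beyond the scatter) and a 160-fold higher number from compound 2 to compound 4 (2.21 log units; beyond the scatter), so this chain end does not accept carboxy as it accepts chloro and hydroxy, which lie within the scatter of each other. Carboxy alone does not set the whole of the high number of compound 1: 2-carboxyethyl in place of carboxymethoxy gives a 26-fold lower number from compound 1 to compound 4 (1.42 log units; beyond the scatter), so the way the carboxy group is attached to the core also counts. Nothing available here explains either change.

On these data alone, whether an amine or a methyl ester at the same chain end tracks hydroxy or carboxy remains open. Also open, as far as these compounds go, is how a carboxylic acid on a longer chain would read.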